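Aryl exchange on the core nitrogen: cytotoxicity notes

This account rests on a few compounds, and the source may have more. Where it says the series, first, only, none or still open, it means among the compounds named here.

compound 1 `Cc1ccccc1-c1nn(-c2ccccc2Cl)cc1CNCCN1CCN(C)CC1` — > 20000 nM
compound 2 `CN1CCN(CCNCc2cn(-c3ccc(F)cc3F)nc2-c2ccccc2)CC1` — > 20000 nM

Both measured compounds were run in an ADME assay on Huh-7 cells (Homo sapiens) for cytotoxicity; a lower number here means that less compound is tolerated, a higher number that more compound is tolerated. Compound 1 reaches only the limit of the assay, > 20000 nM, which is not a number. Compound 2 likewise gives a limit, > 20000 nM. Going by the values given here, compound 1 therefore stands at the limit of > 20000 nM in this assay, at which 2 of the 2 values shown sit; nothing measured separates it from compound 2, and no step between measured compounds can be read off.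

Compound 3 `Cc1ccccc1-c1nn(-c2ccc(F)c(F)c2)cc1CNCCN1CCN(C)CC1` is the unmeasured member. It differs from compound 1 by 3,4-difluorophenyl in place of 2-chlorophenyl on an aromatic nitrogen, in words 3,4-difluorophenyl in place of 2-chlorophenyl on an aromatic nitrogen. Among the compounds with values here, no measured step informs this change. The step that the limit leaves unreadable from compound 1 to compound 3 is expected to be none beyond the scatter, with the assay most likely again returning only a limit. For compound 3 the estimate is 30000 nM, within a range from 10000 nM to 100000 nM.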

Compound 3, half-maximal cytotoxic concentration: > 20000 nM
Compound 3: no number, only a limit (the forecaster's own chance of this, stated with the estimate: 80%); the middle value lies beyond the limit too.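

In this assay, going by these compounds alone, compound 3 gives > 20000 nM, a limit and not a number, so no step from compound 1 to compound 3 can be read. The compounds shown leave open whether any aryl exchange on the core nitrogen changes the tolerated concentration, with all of them at one value: the limit of > 20000 nM in this assay, at which 3 of the 3 values shown sit.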